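Swapping the aryl group on a labdane-type acid: cytotoxicity outlook

A few compounds are considered here, and "the series" means these few. Any claim that something is new, unique, unknown or untested is made for them only; others in the source may bear on it.

Compound 1 `Cc1ccc(/C=C2\CC[C@H]3C(C)(C)CCC[C@]3(C)[C@H]2CCC(C)CC(=O)O)cc1`: > 200000 nM
Compound 2 `COc1ccc(/C=C2\CC[C@H]3C(C)(C)CCC[C@]3(C)[C@H]2CCC(C)CC(=O)O)cc1OC`: > 200000 nM

In an ADME assay on HUVEC cells (Homo sapiens) for cytotoxicity, read by MTT assay, with a stated time of 72 h (on this read-out lower numbers stand for stronger inhibition and higher numbers for weaker inhibition), compound 1 gives > 200000 nM, which is a limit of the assay rather than a number. In this assay compound 2 likewise gives > 200000 nM, again a limit. The step that the two limits leave unreadable from compound 1 to compound 2 therefore cannot be read, and the limit of > 200000 nM in this assay, at which 2 of the 2 values shown sit, describes where both sit. Compound 3 `CC(CC[C@H]1/C(=C/c2ccc(Cl)cc2)CC[C@H]2C(C)(C)CCC[C@]12C)CC(=O)O` carries the change (4-chlorophenyl in place of 3,4-dimethoxyphenyl on a double-bonded chain carbon bound to a double-bonded ring carbon). No readable step bears on it, so the expected step of a number no higher from compound 2 to compound 3 (the limit leaves the size open) is essentially none beyond the scatter. Compound 3 is estimated at 200000 nM, with a range from 80000 nM to 500000 nM, most likely reported again as a limit.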

Compound 3, half-maximal inhibitory concentration: > 200000 nM
Compound 3 gave a limit, no number; the forecaster's own chance of this, stated with the estimate: 85%; the middle value lies on the limit itself.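

For the compounds shown here, compound 3 gives > 200000 nM in this assay, a limit and not a number, so no step from compound 1 or compound 2 to compound 3 can be read. Going by these compounds, whether compound 1, compound 2 and compound 3 differ at all in this assay stays open.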